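Ester truncation on two benzyl variants of the shared core

The compounds below may be only part of what the source reports. "The series", "measured", "known", "first", "only" and "open" are said of these compounds alone.

Compound 1 `CC(C)[C@H](N)C(=O)OCCCOC1(c2ccc(Cl)cc2)c2ccccc2C(=O)N1Cc1ccc(Cl)cc1` carries the (1-amino-2-methylpropyl)carbonyl ester and the 4-chlorobenzyl group; in a functional assay on HCT-116 cells (Homo sapiens) for inhibition, read by fluorescence, with a stated time of 48 h (on this read-out higher numbers stand for weaker inhibition of growth and lower numbers for stronger inhibition of growth), compound 1 gives 16000 nM. Compound 2 `CC(=O)OCCCOC1(c2ccc(Cl)cc2)c2ccccc2C(=O)N1Cc1ccc(Cl)cc1` keeps the 4-chlorobenzyl group but carries the acetyl ester; in this assay compound 2 gives 46000 nM. The change methyl in place of 1-amino-2-methylpropyl on a carbonyl carbon brings a 2.9-fold higher number from compound 1 to compound 2 (0.46 log units; beyond the scatter). Compound 3 `CC(C)[C@H](N)C(=O)OCCCOC1(c2ccc(Cl)cc2)c2ccccc2C(=O)N1Cc1ccccc1` retains the (1-amino-2-methylpropyl)carbonyl ester, its core differing from that of compound 1 by hydrogen in place of chloro on an aromatic carbon; in this assay compound 3 gives 20000 nM, the step being a 1.3-fold higher number from compound 1 to compound 3 (0.10 log units; within the scatter). Compounds 1 and 3 are thus not separated by this assay.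

Compound 4 `CC(=O)OCCCOC1(c2ccc(Cl)cc2)c2ccccc2C(=O)N1Cc1ccccc1`, not yet measured, differs from compound 3 by methyl in place of 1-amino-2-methylpropyl on a carbonyl carbon. This is the same change as from compound 1 to compound 2, now made on the core of compound 3; the surroundings of the place are the same word for word. Among the four compounds the change occurs twice, once with both ends measured.

Among the measured compounds shown here, for compound 4 the expected step is a 2.8-fold higher number from compound 3 to compound 4 (0.44 log units; beyond the scatter), about the size seen earlier, because a 2.9-fold higher number from compound 1 to compound 2 (0.46 log units; beyond the scatter) was the only measured instance and the core difference moved the number only by a 1.3-fold higher number from compound 1 to compound 3 (0.10 log units; within the scatter). Compound 4 is expected in this assay to give 55000 nM, within the estimated range 25000 nM to 120000 nM. This rests on a single measured pair, so the range is kept wide.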

Compound 4, concentration for 50% growth inhibition: 50000 nM
Compound 4: the middle estimate sits 1.1-fold (0.04 log units) above what was measured; the measured number falls inside the stated range.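

The step of a 2.5-fold higher number from compound 3 to compound 4 (0.40 log units; beyond the scatter) matches the one seen on the core of compound 1, so exchanging 1-amino-2-methylpropyl for methyl on the carbonyl carbon carries across the two benzyl variants in this assay with no measurable change in size: the same change on two cores in this assay, a 2.9-fold higher number (0.46 log units; beyond the scatter) from compound 1 to compound 2 and a 2.5-fold higher number (0.40 log units; beyond the scatter) from compound 3 to compound 4, 1.2-fold (0.06 log units) apart, within the scatter of two such steps
The chloro-to-hydrogen change, now read as a 1.1-fold higher number from compound 2 to compound 4 (0.04 log units; within the scatter), also stays within the scatter on the acetyl ester, as it did on the (1-amino-2-methylpropyl)carbonyl ester: the same change on two cores in this assay, a 1.3-fold higher number (0.10 log units; within the scatter) from compound 1 to compound 3 and a 1.1-fold higher number (0.04 log units; within the scatter) from compound 2 to compound 4, 1.2-fold (0.06 log units) apart, within the scatter of two such steps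
The four compounds thus show the two changes acting independently in this one set, but they do not show that this holds for other benzyl substituents or other esters, and they give no explanation for the step.

The ester change removes both the amine and the branched carbon chain at once, so an aminomethyl or an isopropyl group in place of 1-amino-2-methylpropyl would be needed to tell which part carries the step. Also open, on these data alone, is whether the transfer survives a methoxy or a fluoro on the benzyl group, an amide in place of the ester, or a longer chain in place of the one carrying the ester.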